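The source may report more compounds than this note shows. Statements on the series, on what has been measured and on what is new or still open speak of the compounds shown alone.

Compound 1 `CN(C)CCn1cnnc1-c1cc(Oc2ccc(NC(=O)N/N=C/c3c[nH]c4ccccc34)cc2F)ccn1` belongs to a set of three compounds that share a core and differ only in the group attached to the carbon with a double bond to nitrogen. In a functional assay on HT-29 cells (Homo sapiens) for cytotoxicity, read by MTT assay, with a stated time of 72 h (a higher number here means a weaker inhibitor, a lower number a stronger inhibitor), compound 1 gives 1300 nM, the lowest of the three numbers, though both neighbours lie within the scatter of it. Compound 2 `COc1ccc(OC)c(/C=N/NC(=O)Nc2ccc(Oc3ccnc(-c4nncn4CCN(C)C)c3)c(F)c2)c1` gives 2070 nM, and compound 3 `CN(C)CCn1cnnc1-c1cc(Oc2ccc(NC(=O)N/N=C/c3ccc(F)cc3)cc2F)ccn1` gives 1370 nM. The steps that leave compound 1 are small: a 1.6-fold higher number from compound 1 to compound 2 (0.20 log units; within the scatter) and a 1.1-fold higher number from compound 1 to compound 3 (0.02 log units; within the scatter), and between the two others a 1.5-fold lower number from compound 2 to compound 3 (0.18 log units; within the scatter).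

Compound 4 `CN(C)CCn1cnnc1-c1cc(Oc2ccc(NC(=O)N/N=C/c3cccc(Cl)c3Cl)cc2F)ccn1` has not yet been measured. It differs from compound 1 as follows: 2,3-dichlorophenyl in place of 1H-indol-3-yl on a carbon with a double bond to nitrogen. Both measured steps from compound 1 replaced the 1H-indol-3-yl with a substituted phenyl and stayed within the scatter, so no step beyond the scatter is expected here either, in either direction. For compound 4 the estimated value is 1400 nM, with a range from 700 nM to 2800 nM. This estimate means an expected step of a 1.1-fold higher number from compound 1 to compound 4 (0.03 log units; within the scatter).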

Compound 4, half-maximal inhibitory concentration: 130 nM
The estimate for compound 4 lay 11-fold (1.03 log units) above the measured number, and the stated range ends above it.
By their numbers in this assay, from the lowest: compound 4; then compounds 1, 3 and 2 (each within the scatter of the next).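

Where 1H-indol-3-yl, 4-fluorophenyl and 2,5-dimethoxyphenyl could not be told apart in this assay, the group on the carbon with a double bond to nitrogen now makes a clear difference: 2,3-dichlorophenyl gives a 10-fold lower number from compound 1 to compound 4 (1.00 log units; beyond the scatter), along with an 11-fold lower number from compound 3 to compound 4 (1.02 log units; beyond the scatter) and a 16-fold lower number from compound 2 to compound 4 (1.20 log units; beyond the scatter). A halogen on the phenyl ring is not enough by itself, as compound 3, with its 4-fluorophenyl, stays within the scatter of compound 1. Nothing measured here explains what lies behind this drop.

The compounds shown leave open whether both chlorines are needed, and whether chlorine itself matters or any similar pair of groups would do. A phenyl ring with a single chlorine, or with methyl groups in place of the chlorines, would bear on both questions.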